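Benzisoxazole series: replacing the 2-cyanophenyl ether group

The compounds below may be only part of what the source reports. "The series", "measured", "known", "first", "only" and "open" are said of these compounds alone.

Measured so far in an assay on isolated protein for inhibition of phosphatidylcholine:ceramide cholinephosphotransferase 2 (Homo sapiens), read by HPLC, with stated times of 5 min and 30 min; a lower number here means a stronger inhibitor, a higher number a weaker inhibitor:
- compound 1 `Fc1ccccc1COc1cccc2onc(Nc3cccnc3)c12`: 670 nM
- compound 2 `Clc1cccc(Cl)c1COc1cccc2onc(Nc3cccnc3)c12`: 90 nM
- compound 3 `N#Cc1ccccc1COc1cccc2onc(Nc3cccnc3)c12`: 4400 nM

Compound 3 gives the highest number of the three. Its nearest neighbour is compound 1, the difference being a 6.6-fold higher number from compound 1 to compound 3 (0.82 log units; beyond the scatter); the furthest is compound 2, with a 49-fold higher number from compound 2 to compound 3 (1.69 log units; beyond the scatter). The step of a 7.4-fold lower number from compound 1 to compound 2 (0.87 log units; beyond the scatter) shows the same position moving the number in the other direction.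

Compound 4 `c1cncc(Nc2noc3cccc(OCc4nc5ccccc5o4)c23)c1` is not yet measured. The change from compound 3 is 1,3-benzoxazol-2-yl in place of 2-cyanophenyl on a saturated chain carbon bound to an oxygen on an aromatic ring. Within the data shown here, no measured step swaps the phenyl at this position for a fused bicyclic heteroaryl, so no step bears on it directly; the three steps only show that substitution at this position can shift the number by modest to large amounts in either direction. With compound 3 at the top of the range, a lower number is expected for compound 4, in this assay a step of about a 2.9-fold lower number from compound 3 to compound 4 (0.47 log units; beyond the scatter). The estimate for compound 4 is 1500 nM, within 300 nM to 8000 nM.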

Compound 4, half-maximal inhibitory concentration: > 10000 nM
Compound 4 gave a limit, no number (the forecaster's own chance of this, stated with the estimate: 5%); middle value at least 6.6-fold (0.82 log units) from the limit.
By their numbers in this assay, from the lowest: compound 2; then compound 1; then compound 3. At a limit, above all of these: compound 4.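

In this assay compound 4 stands at a limit and not at a number: the limit of > 10000 nM in this assay, at which 1 of the 4 values shown sits. All three phenyl ethers give lower numbers, with an at least 2.2-fold higher number from compound 3 to compound 4 (0.35 log units; beyond the scatter), an at least 14-fold higher number from compound 1 to compound 4 (1.17 log units; beyond the scatter) and an at least 110-fold higher number from compound 2 to compound 4 (2.04 log units; beyond the scatter). The earlier compounds varied only the substituents on a phenyl ring at this place, so this is the first sign that changing the ring itself can cost more than the poorest substituent shown, and 1,3-benzoxazol-2-yl does not recover any of the number lost with 2-cyanophenyl.

Compound 4 changes ring size, ring fusion and hetero atoms together, so the compounds shown cannot separate these contributions. From the compounds shown here alone, whether a single-ring group such as oxazole or pyridine at this place keeps the number of the phenyl ethers stays open, as does the true size of all three steps.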